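A few compounds are considered here, and "the series" means these few. Any claim that something is new, unique, unknown or untested is made for them only; others in the source may bear on it.

Of the compounds shown here, two have been measured so far in a functional assay on AGS cells (Homo sapiens) for inhibition, read by reporter gene assay; on this read-out higher numbers stand for weaker inhibition and lower numbers for stronger inhibition. Compound 1, `CC(=O)c1ccc(OCC(=O)Nc2cccc(C(=O)O)c2)cc1`, gives > 30000 nM, which is a limit of the assay and not a number. Compound 2, `Cc1ccc(OCC(=O)Nc2cccc(C(N)=O)c2)cc1`, gives > 30000 nM, again a limit. Among the compounds with values here, the record so far therefore shows (the limit of > 30000 nM in this assay, at which 2 of the 2 values shown sit), and it contains no measured step to learn from.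

Compound 3, `COc1cccc(-c2ccc(OCC(=O)Nc3cccc(C(=O)O)c3)cc2)c1`, keeps the core of compound 1 and changes one place: 3-methoxyphenyl in place of acetyl on an aromatic carbon. In words, 3-methoxyphenyl stands in place of acetyl on an aromatic carbon, para to a large group. This swap brings in an aromatic ring, which makes it a sizeable structural change. Compound 1 reads > 30000 nM, a limit, so any measurable change can only be seen toward stronger inhibition. A moderate gain is the expectation, although a second result at the limit would be no surprise. The expected change is an at least 3.7-fold lower number from compound 1 to compound 3 (0.57 log units; beyond the scatter), beyond the usual scatter if it appears. Compound 3 is estimated at 8000 nM, with an expected range from 1500 nM to 30000 nM.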

Compound 3, half-maximal inhibitory concentration: 35000 nM
Beside the measured number, compound 3's estimate is 4.4-fold (0.64 log units) below it; measured number outside the range, above it.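

No step can be read between compound 1 and compound 3, because compound 1 gives a limit and not a number: the limit of > 30000 nM in this assay, at which 2 of the 3 values shown sit. The compounds shown leave open whether 3-methoxyphenyl in place of acetyl changes inhibition at all, and which change to the shared core would bring a reading clearly stronger than this limit.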